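Solubility of a larger saturated ring in place of cyclopentyl

The source may report more compounds than this note shows. Statements on the series, on what has been measured and on what is new or still open speak of the compounds shown alone.

Of the compounds shown here, three sharing one core have been measured in a physicochemical assay for solubility, using the shake flask method, in phosphate buffer, measured as kinetic solubility, with a stated time of 20 h, at pH 6.5; a lower number here means a less soluble compound, a higher number a more soluble compound. For the measured compounds named here, compound 3 `FC(F)(F)c1ccc(Nc2cc3[nH]c(C4CCCC4)nc3cn2)nc1` gives 145000 nM, the only true number in the set. Compound 1 `FC(F)(F)c1cccc(-c2nc3cnc(Nc4ncccn4)cc3[nH]2)c1` sits at a limit of this assay, < 5000 nM. Compound 2 `N#Cc1ccc(Nc2cc3[nH]c(-c4cccc(C(F)(F)F)c4)nc3cn2)nc1` likewise sits at a limit, < 5000 nM. Going by the values given here, the one measured step, a step that the two limits leave unreadable from compound 1 to compound 2, cannot be sized because of the limit of < 5000 nM in this assay, at which 2 of the 3 values shown sit, so no measured step bears on the change to compound 4 `FC(F)(F)c1ccc(Nc2cc3[nH]c([C@H]4CC[C@H](C(F)(F)F)CC4)nc3cn2)nc1`, which carries 4-(trifluoromethyl)cyclohexyl in place of cyclopentyl on an aromatic carbon. With nothing comparable measured, the direction is an expectation only: compound 4 is estimated to be less soluble than compound 3, a step of a 7.3-fold lower number from compound 3 to compound 4 (0.86 log units; beyond the scatter). Compound 4 is therefore expected to give about 20000 nM, between 5000 nM and 80000 nM, with some chance that this assay reports only a limit.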

Compound 4, solubility: < 5000 nM
Compound 4: no number, only a limit; the forecaster's own chance of this, stated with the estimate: 25%; middle value at least 4.0-fold (0.60 log units) from the limit.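

In this assay, for the compounds shown here, the change at this aromatic carbon gives the first step that can be read, an at least 29-fold lower number from compound 3 to compound 4 (1.46 log units; beyond the scatter). Compound 4 gives only a limit, < 5000 nM, so that step is a bound and not an exact size. Compound 3 remains the only compound here with a true number in this assay: the limit of < 5000 nM in this assay, at which 3 of the 4 values shown sit.

The compounds shown leave open whether the step follows the six-membered ring or the trifluoromethyl group, as plain cyclohexyl does not stand among them. They also leave open whether an amine or a carboxylic acid in place of that trifluoromethyl group would give a true number.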